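Working notes: from compound 1 to compound 4

The source may report more compounds than this note shows. Statements on the series, on what has been measured and on what is new or still open speak of the compounds shown alone.

- compound 1 `Cc1ccc(C)c(N2CCN(C(=O)c3oc(C)nc3-c3ccccc3)CC2)c1`: 1.73 ug/mL
- compound 2 `COc1cc(OC)cc(N2CCN(C(=O)c3oc(C)nc3-c3ccccc3F)CC2)c1`: 0.118 ug/mL
- compound 3 `CCC[C@H](Nc1nc(-c2ccc(NC(=O)NCC)c(OC)c2)ncc1C)c1cccnc1`: 2.1 ug/mL

In a toxicity assay on HUVEC cells (Homo sapiens) for inhibition (a higher number here means a weaker inhibitor of growth, a lower number a stronger inhibitor of growth), compound 1 lies within the scatter of compound 3, while the gap down to compound 2 lies beyond the scatter. Compound 4 `Cc1nc(-c2ccccc2)c(C(=O)N2CCN(c3cc(Cl)cc(Cl)c3)CC2)o1`, not yet measured, keeps the core of compound 1, with 3,5-dichlorophenyl in place of 2,5-dimethylphenyl on an amine nitrogen in a ring. Among the measured compounds shown here, no measured pair isolates this change. Compound 2, at 0.118 ug/mL, differs from compound 1 in more than one place, so it gives only a weak hint toward lower numbers. A small move toward a lower number is expected, a 2.2-fold lower number from compound 1 to compound 4 (0.33 log units; beyond the scatter). For compound 4 the estimated value is 0.8 ug/mL, with an expected range of 0.15 ug/mL to 3 ug/mL.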

Compound 4, concentration for 50% growth inhibition: 0.191 ug/mL
Beside the measured number, compound 4's estimate is 4.2-fold (0.62 log units) above it; the measured number falls inside the stated range.
By their numbers in this assay, from the lowest: compounds 2 and 4 (each within the scatter of the next); then compounds 1 and 3 (each within the scatter of the next).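

In this assay, among the compounds shown here, 3,5-dichlorophenyl in place of 2,5-dimethylphenyl on the amine nitrogen in a ring gives a 9.1-fold lower number from compound 1 to compound 4 (0.96 log units; beyond the scatter), a one-place reading that the earlier compounds did not offer. This position therefore affects the number with the rest of the core of compound 1 unchanged, although the two groups match in heavy-atom count and in hydrogen-bond donors and acceptors. Nothing available explains the step.

On these data alone, the change replaces both the substituent type and its placement, so the share of each remains open. Also open, as far as these compounds go, is how a nitrile or a carboxylic acid on this phenyl ring would compare.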